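The compounds below may be only part of what the source reports. "The series", "measured", "known", "first", "only" and "open" are said of these compounds alone.

Compound 1 `CC(C)C[C@H](N)c1cc(C(F)(F)F)ccc1N1CCN(C(=O)CCC(N)=O)CC1` stands at the edge of an assay on HEK293 cells for displacement of a labelled ligand from Melanocortin receptor 4 (Homo sapiens); a lower number here means a stronger inhibitor, a higher number a weaker inhibitor: compound 1 gives > 10000 nM, which is a limit of the assay rather than a measured number (the limit of > 10000 nM in this assay, at which 1 of the 2 values shown sits). Compound 2 `COc1cc(Cl)ccc1C[C@@H](C)C(=O)N1CCN(c2ccc(C)cc2[C@@H](N)CC(C)C)CC1`, whose acyl chain carries a chlorine-bearing aromatic ring, gives 8.1 nM in this assay. Compound 3 `CC(C)C[C@H](N)c1cc(C(F)(F)F)ccc1N1CCN(C(=O)COc2ccc(Cl)cc2)CC1` differs from compound 1 in one place (4-chlorophenoxy in place of carbamoylmethyl on a saturated chain carbon bound to a carbonyl carbon). Going by the values given here, no measured step joins the two, so the size of the change is an expectation; a large gain in binding is expected because compound 2 gives 8.1 nM with a related chlorine-bearing ring. Compound 3 is expected to reach 150 nM, between 25 nM and 1500 nM. The expected step is an at least 66-fold lower number from compound 1 to compound 3 (1.82 log units; beyond the scatter).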

Compound 3, inhibition constant: 2900 nM
For compound 3 the middle estimate is 19-fold (1.29 log units) below the measured one, and the stated range ends below it.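

Exchanging the carbamoylmethyl group for a 4-chlorophenoxy group brings the compound into the measurable range of this assay, with an at least 3.4-fold lower number from compound 1 to compound 3 (0.53 log units; beyond the scatter). This position therefore responds to the group it carries, and binding can be read here with an aromatic ring in place. The value of compound 1 is a limit of the assay, so the true size of the step stays open: the limit of > 10000 nM in this assay, at which 1 of the 3 values shown sits.

As far as these compounds go, whether the gain depends on the chlorine, the ether oxygen or the ring itself remains open. So does how a plain phenoxy group, a 4-methoxyphenoxy group or a longer chain would read at this position.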